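The source may report more compounds than this note shows. Statements on the series, on what has been measured and on what is new or still open speak of the compounds shown alone.

Compound 1 `CC(F)(F)c1nc([C@@H](O)[C@H](O)[C@H](O)CO)c[nH]1`: 1 h
Compound 2 `OC[C@@H](O)[C@@H](O)[C@H](O)c1c[nH]c(C(F)(F)C(F)(F)F)n1`: 1.7 h
Compound 3 `OC[C@@H](O)[C@@H](O)[C@H](O)c1c[nH]c(-c2ncccn2)n1`: not yet measured

In an ADME assay on the whole organism (strain 129/SvEvBrd x C57BL/6) for metabolic stability, with Mus musculus as the target (on this read-out higher numbers stand for a longer-lived compound and lower numbers for a shorter-lived compound), compound 1 gives 1 h, and compound 2 gives 1.7 h, so the two stand within the scatter of each other. The change to compound 3 is pyrimidin-2-yl in place of 1,1-difluoroethyl on an aromatic carbon. Going by the values given here, the one measured step, a 1.7-fold higher number from compound 1 to compound 2 (0.23 log units; within the scatter), only alters the chain and brings in no ring, so it bears on this change weakly. No step beyond the scatter is expected, in either direction. The expected step is a 1.3-fold higher number from compound 1 to compound 3 (0.11 log units; within the scatter). Compound 3 is estimated at 1.3 h, with an expected range of 0.5 h to 3.5 h.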

Compound 3, half-life: 2.4 h
For compound 3 the middle estimate is 1.8-fold (0.27 log units) below the measured one; the measured number falls inside the stated range.
By their numbers in this assay, from the lowest: compounds 1, 2 and 3 (each within the scatter of the next, the first and the last beyond it).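

In this assay, going by these compounds alone, the place between two ring nitrogen atoms takes an aromatic ring as well as a fluorinated chain: pyrimidin-2-yl in place of 1,1-difluoroethyl gives a 2.4-fold higher number from compound 1 to compound 3 (0.38 log units; beyond the scatter), the first step beyond the scatter, though a modest one. No measurement at hand accounts for this step.

On these data alone, whether the ring itself or its nitrogen atoms matter stays open, and a phenyl or pyridin-2-yl group at this place would separate the two. As far as these compounds go, how an amine or a carboxylic acid would fare here is also open.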